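This account rests on a few compounds, and the source may have more. Where it says the series, first, only, none or still open, it means among the compounds named here.

Compound 1, with the structure `CCc1cccc(NC(=O)N[C@H](C)c2ccccc2)c1`, was tested in an ADME assay on the whole organism with Oryza sativa as the target, tested at 0.1 uM (on this read-out higher numbers stand for a weaker effect at the one concentration tested and lower numbers for a stronger effect), and gives 97%. Two companions were measured alongside it. Compound 2, `CCc1cccc(NC(=O)N[C@@H](C)c2ccccc2)c1`, gives 100% in this assay, and compound 3, `C[C@@H](NC(=O)Nc1ccc(C(C)(C)C)cc1)c1ccccc1`, gives 100%. All three numbers lie within the usual scatter of one another, so compound 1 cannot be set apart from either of the other two on these data. Going by the values given here, the only step between neighbours that differ in one place is a number 3 percentage points higher from compound 1 to compound 2 (within the scatter), and it rests on (the fact that compounds 1 and 2 differ only in the configuration as drawn).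

Compound 4, `C[C@@H](NC(=O)Nc1cccc(Br)c1)c1ccccc1`, has not yet been measured. Compared with compound 1 the change is bromo in place of ethyl on an aromatic carbon. Among the compounds with values here, no measured step exchanges one group for another on the shared core; the single step available concerns configuration only and stayed within the scatter. With nothing pointing toward a stronger effect, the expectation for compound 4 is a number close to that of compound 1, and the step of no change at the digits printed from compound 1 to compound 4 (within the scatter) is expected to stay within the scatter. For compound 4 the estimate in this assay is 97%, with a likely range from 85% to 100%.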

Compound 4, a percentage reported as activity, at one concentration (the size of the read-out at that concentration, not a potency): 100%
Compound 4: the middle estimate sits 3 percentage points below what was measured; the measured number falls inside the stated range.
By their numbers in this assay, from the lowest: compounds 1, 2, 3 and 4 (each within the scatter of the next).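

In this assay the place of ethyl on the aromatic carbon, meta to a large group, can be taken by bromo with a step of a number 3 percentage points higher from compound 1 to compound 4 (within the scatter) and no effect that can be told apart. Going by these compounds alone, this is the first measured exchange of one group for another on the shared core, whereas the earlier step concerned configuration only, and it shows that this position tolerates a two-carbon chain and a single bromine atom alike on this read-out. No information at hand explains this result.

On these data alone, whether an amine, a carboxylic acid or a longer chain at this position would move the number beyond the scatter remains open. All four compounds lie within the scatter of the next, so they do not show what, if anything, gives a stronger effect at the one concentration tested.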